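Compound 3 to Compound 4: a Simpler Amide Partner

A few compounds are considered here, and "the series" means these few. Any claim that something is new, unique, unknown or untested is made for them only; others in the source may bear on it.

Measured compounds:
- compound 1 `O=C(Nc1cccc(-n2cc(-c3ccncc3)c(-c3ccc(Cl)c(O)c3)n2)c1)Nc1ccc(Cl)c(Cl)c1`: 2740 nM
- compound 2 `COc1cc(-c2nn(-c3cccc(NC(=O)c4ccc(Cl)c(C(F)(F)F)c4)c3)cc2-c2ccncc2)ccc1Cl`: 1290 nM
- compound 3 `COc1cc(-c2nn(-c3cccc(NC(=O)Nc4cccc(C(F)(F)F)c4)c3)cc2-c2ccncc2)ccc1Cl`: 783 nM

In a functional assay on NCI/ADR-RES cells (Homo sapiens) for inhibition, read by sulforhodamine B assay, with a stated time of 48 h (on this read-out lower numbers stand for stronger inhibition of growth and higher numbers for weaker inhibition of growth), compound 3 gives 783 nM, the lowest of the three numbers. Compound 2 sits nearest, its number higher by a margin that is within the scatter, while compound 1 stands furthest, its number higher by a margin beyond the scatter. Compound 4 `COc1cc(-c2nn(-c3cccc(NC(=O)c4ccccc4)c3)cc2-c2ccncc2)ccc1Cl` has not yet been measured in this assay. It differs from compound 3 in one place: phenyl in place of (3-(trifluoromethyl)phenyl)amino on a carbonyl carbon.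

Among the compounds with values here, only one measured step bears on this change. Going a 1.6-fold lower number from compound 2 to compound 3 (0.22 log units; within the scatter) also swapped an aryl group on the carbonyl carbon for an arylamino group, and that step stayed within the scatter. Compound 4 goes the other way, back to an aryl group on the carbonyl carbon as in compound 2, but its phenyl carries none of the groups that compound 2 has. Nothing measured shows what removing the trifluoromethyl alone does, so the expectation rests on compound 2 and compound 3 lying close together. The expected step is a 2.8-fold higher number from compound 3 to compound 4 (0.45 log units; beyond the scatter), a modest rise in the number. The estimate for compound 4 is 2200 nM, with a range from 800 nM to 6000 nM.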

Compound 4, concentration for 50% growth inhibition: 448 nM
The estimate for compound 4 lay 4.9-fold (0.69 log units) above the measured number; the measured number lies below the stated range.
By their numbers in this assay, from the lowest: compounds 4, 3 and 2 (each within the scatter of the next, the first and the last beyond it); then compound 1.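

In this assay the group on the carbonyl carbon can be cut back to plain phenyl with no loss that the measurements can detect: the exchange for (3-(trifluoromethyl)phenyl)amino gives a 1.7-fold lower number from compound 3 to compound 4 (0.24 log units; within the scatter) and so neither the trifluoromethyl nor the hydrogen-bond donor of the leaving group is needed to hold this level of growth inhibition. The comparison with the amide partner that carries more substituents goes further, as phenyl in place of 4-chloro-3-(trifluoromethyl)phenyl gives a 2.9-fold lower number from compound 2 to compound 4 (0.46 log units; beyond the scatter) and here the bare ring inhibits growth more strongly than the substituted one. No measurement at hand explains why the simpler group does this well.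

Which of the chlorine and the trifluoromethyl in compound 2 accounts for its higher number stays open, as no compound here with an aryl group directly on the carbonyl carbon carries one without the other. Also open, on these data alone, is how far the position reaches beyond plain aromatic rings, for instance to a cyclohexyl ring, a short alkyl chain, or a phenyl bearing an amine or a carboxylic acid.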